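The compounds below may be only part of what the source reports. "The series", "measured", "known", "first", "only" and "open" are said of these compounds alone.

Measured so far:
compound 1 `COc1ccc(/C=C2\CN(C(=S)SCc3cn(Cc4ccccc4Cl)nn3)C/C(=C\c3ccc(OC)cc3)C2=O)cc1`: > 100000 nM
compound 2 `O=C1/C(=C/c2ccccc2F)CN(C(=S)SCc2cn(Cc3cccc(Cl)c3)nn2)C/C1=C\c1ccccc1F`: > 100000 nM
compound 3 `Cc1ccc(/C=C2\CN(Cc3cn(Cc4ccccc4Cl)nn3)C/C(=C\c3ccc(C)cc3)C2=O)cc1`: 29000 nM

In a functional assay on MDA-MB-231 cells (Homo sapiens) for cytotoxicity, read by MTT assay, with a stated time of 24 h (on this read-out lower numbers stand for stronger inhibition and higher numbers for weaker inhibition), compound 2 gives only > 100000 nM, which is a limit of the assay and not a number. Compound 1 likewise stops at a limit, > 100000 nM. Among the measured compounds shown here, compound 3 is the one compound of the three with a number, 29000 nM. Compound 2 therefore stands at the edge of what this assay reports, namely (the limit of > 100000 nM in this assay, at which 2 of the 3 values shown sit).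

Compound 4 `O=C1/C(=C/c2ccccc2F)CN(C(=S)SCc2cn(Cc3ccccc3F)nn2)C/C1=C\c1ccccc1F` has not yet been run in this assay. Against compound 2 the change is 2-fluorophenyl in place of 3-chlorophenyl on a saturated chain carbon bound to an aromatic nitrogen. For the measured compounds named here, no pair among the measured compounds differs in one place, so no measured step shows what such a swap does; compound 1 and compound 2 share the same limit while differing in more than one place, and compound 3 differs from both in several places at once.

With compound 2 at a limit, the expected step from compound 2 to compound 4 is a step that the limit leaves unreadable from compound 2 to compound 4, that is, none beyond the scatter. Compound 4 is expected to come out near 150000 nM, between 60000 nM and 400000 nM, most likely once more as a limit rather than as a number.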

Compound 4, half-maximal inhibitory concentration: 57600 nM
Beside the measured number, compound 4's estimate is 2.6-fold (0.42 log units) above it; measured number outside the range, below it.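

In this assay, 2-fluorophenyl in place of 3-chlorophenyl on a saturated chain carbon bound to an aromatic nitrogen gives an at least 1.7-fold lower number from compound 2 to compound 4 (0.23 log units; that floor lies within the scatter). Among the compounds shown here, this is the first step with a single point of difference, and with the rest of the structure unchanged, compound 4 gives a measured number, 57600 nM. The full size of the step cannot be read because compound 2 stands at a limit of the assay, not at a number: the limit of > 100000 nM in this assay, at which 2 of the 4 values shown sit.

The change alters both the halogen and its place on the ring, so the compounds shown leave open which of the two carries the step, and whether the same swap would act alike on the core of compound 3. Also open, going by these compounds, is how a benzyl group carrying a carboxylic acid or an amine would read at this position.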